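The source may report more compounds than this note shows. Statements on the series, on what has been measured and on what is new or still open speak of the compounds shown alone.

Compound 1 `CCOC(=O)c1cnc(-c2ccccc2OCC)[nH]c1=O` gives 2 mg/kg
Compound 2 `CCOC(=O)c1cnc(-c2cc(Cl)ccc2OCC)[nH]c1=O` gives 0.5 mg/kg
Compound 3 `CCOC(=O)c1cnc(-c2cc([N+](=O)[O-])ccc2OCC)[nH]c1=O` gives 5 mg/kg

In a functional assay on the whole organism (strain Sprague-Dawley) for inhibition, with Rattus norvegicus as the target, with a stated time of 10 min (a lower number here means that less compound is needed, a higher number that more compound is needed for the effect), compound 3 has the highest number of the three, so it needs the most compound for the effect. Compound 4 `CCOC(=O)c1cnc(-c2cc(N)ccc2OCC)[nH]c1=O` has amino in place of nitro on an aromatic carbon. Within the data shown here, no measured step involves amino, so the evidence is indirect. Nitro in place of hydrogen gave a 2.5-fold higher number from compound 1 to compound 3 (0.40 log units; beyond the scatter) and nitro in place of chloro gave a 10-fold higher number from compound 2 to compound 3 (1.00 log units; beyond the scatter), so both measured replacements of nitro would point to lower numbers. Chloro in place of hydrogen gave a 4.0-fold lower number from compound 1 to compound 2 (0.60 log units; beyond the scatter) and shows how far this position can move the number. A small step toward a lower number is therefore expected, estimated as a 1.7-fold lower number from compound 3 to compound 4 (0.22 log units; within the scatter) here. The estimate for compound 4 is 3 mg/kg, with an expected range from 0.8 mg/kg to 11 mg/kg.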

Compound 4, dose for 50% inhibition: 0.5 mg/kg
Compound 4: the middle estimate sits 6.0-fold (0.78 log units) above what was measured; the whole stated range lies above it.
By their numbers in this assay, from the lowest: compounds 2 and 4 (each within the scatter of the next); then compound 1; then compound 3.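

In this assay, among these compounds, amino in place of nitro gives a 10-fold lower number from compound 3 to compound 4 (1.00 log units; beyond the scatter) and amino in place of hydrogen gives a 4.0-fold lower number from compound 1 to compound 4 (0.60 log units; beyond the scatter) so chloro is not the only group at this position that lowers the number relative to hydrogen. Amino in place of chloro gives no change at the digits printed from compound 2 to compound 4 (within the scatter) while nitro remains the only group shown that raises the number relative to hydrogen. No measurement shown explains the gap between amino and nitro. The compounds shown leave open whether fluoro, methyl or methoxy at this position would also lower the number, and whether an acetylated amine would behave like amino.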